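Swapping a propyl for an ester on a kinase inhibitor

The source may report more compounds than this note shows. Statements on the series, on what has been measured and on what is new or still open speak of the compounds shown alone.

Measured compounds:
compound 1 `CN(C)c1ccc(C(=O)Nc2cccc(NC(=O)COc3ccc4c(c3)OCCC4=O)c2)cc1`: 85 nM
compound 2 `CCCc1ccc(C(=O)Nc2cccc(NC(=O)COc3ccc4c(=O)ccoc4c3)c2)cc1`: 14 nM

Both compounds were tested in an assay on isolated protein for inhibition of Rho-associated protein kinase 2 (Homo sapiens), read by scintillation counting, radiometric assay and 33P incorporation, with a stated time of 40 min, in the presence of a further agent that is not named here; on this read-out higher numbers stand for weaker inhibition and lower numbers for stronger inhibition. Compound 1 gives 85 nM and compound 2 gives 14 nM, so compound 2 stands as the lower of the two numbers, and the gap to compound 1 lies beyond the usual scatter. The two compounds differ in more than one place, so nothing more than this comparison of numbers can be drawn from them.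

Compound 3 `COC(=O)c1ccc(C(=O)Nc2cccc(NC(=O)COc3ccc4c(=O)ccoc4c3)c2)cc1` has not yet been measured. It differs from compound 2 in one place: methoxycarbonyl in place of propyl on an aromatic carbon. Among the measured compounds shown here, no single-change step between measured compounds is available to guide the expectation, so the estimate rests on the value of compound 2 alone. A step of modest size toward a higher number is expected here, with wide uncertainty, because compound 2 at 14 nM is the only anchor. For compound 3 the estimated step is a 2.1-fold higher number from compound 2 to compound 3 (0.33 log units; beyond the scatter). The value for compound 3 is expected to be 30 nM, within the range 8 nM to 120 nM.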

Compound 3, half-maximal inhibitory concentration: 29 nM
Estimate against measurement, compound 3: 1.0-fold (0.01 log units) above, within the range that was stated.
By their numbers in this assay, from the lowest: compound 2; then compound 3; then compound 1.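

In this assay, changing 4-propylphenyl to 4-(methoxycarbonyl)phenyl gives a 2.1-fold higher number from compound 2 to compound 3 (0.32 log units; beyond the scatter), a modest step but one beyond the usual scatter. Among the compounds shown here, this is the first single-change reading at this position, and it shows that the ring carbon para to a large group can carry methoxycarbonyl, with its hydrogen-bond acceptors and double bond, in place of a plain propyl chain at only a modest cost in inhibition. No measurement shown here offers an explanation for the size or direction of this step.

On these data alone, it remains open how the number would respond to a carboxylic acid, an amine or a longer chain such as butyl at this same position. As far as these compounds go, it is also open whether the same swap would give a similar step on the core of compound 1.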